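The source may report more compounds than this note shows. Statements on the series, on what has been measured and on what is new or still open speak of the compounds shown alone.

Measured so far, in a functional assay on UO-31 cells (Homo sapiens) for inhibition, read by sulforhodamine B assay, with a stated time of 48 h; a lower number here means that less compound is tolerated, a higher number that more compound is tolerated:
compound 1 `COc1ccc(-c2cc(/C=C/C(=O)c3ccc(N)cc3)[nH]n2)cc1` — compound 1 gives 5540 nM
compound 2 `COc1ccc(C(=O)/C=C/c2cc(-c3cc(OC)c(OC)c(OC)c3)n[nH]2)cc1OC` — compound 2 gives 5170 nM
compound 3 `COc1ccc(C(=O)/C=C/c2cc(-c3cc(OC)c(OC)c(OC)c3)n[nH]2)cc1` — compound 3 gives 5590 nM

All three numbers lie within the usual scatter of one another. Compound 1 sits nearest to compound 3 and furthest from compound 2, and neither gap exceeds the scatter, so no ordering among the three can be read from this assay. Among the measured compounds shown here, the one step between neighbours that differ in a single place, a 1.1-fold higher number from compound 2 to compound 3 (0.03 log units; within the scatter), removes a methoxy from the aryl ketone side of the shared core and leaves the number essentially unchanged.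

The next compound, compound 4 `COc1ccc(-c2cc(/C=C/C(=O)c3ccc(N)cc3)[nH]n2)cc1OC`, differs from compound 1 by methoxy in place of hydrogen on an aromatic carbon. The added group sits on the ring attached to the core on the side away from the ketone, ortho to a methoxy group and meta to a large group. For the measured compounds named here, no measured step touches that ring directly; the only related step, the change from compound 2 to compound 3, concerns a methoxy on the other ring and stays within the scatter. On that basis the added methoxy in compound 4 is expected to shift this assay little, with a 1.0-fold lower number from compound 1 to compound 4 (0.00 log units; within the scatter) as the estimated step. Compound 4 is estimated at 5500 nM, with a range of 2700 nM to 11000 nM.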

Compound 4, concentration lethal to 50% of the cells: 43200 nM
For compound 4 the middle estimate is 7.9-fold (0.90 log units) below the measured one; measured number outside the range, above it.
By their numbers in this assay, from the lowest: compounds 2, 1 and 3 (each within the scatter of the next); then compound 4.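

In this assay, among the compounds shown here, methoxy in place of hydrogen on an aromatic carbon, ortho to a methoxy group and meta to a large group, gives the first step beyond the scatter: a 7.8-fold higher number from compound 1 to compound 4 (0.89 log units; beyond the scatter). On this core, the added methoxy therefore goes with more compound being tolerated, whereas the three earlier compounds showed no separation at all. The step between compound 2 and compound 3 does not read across to this position and core, as the same exchange of hydrogen and methoxy gives clearly different results in the two settings: the same change on two cores in this assay, a 1.1-fold higher number (0.03 log units; within the scatter) from compound 2 to compound 3 and a 7.8-fold lower number (0.89 log units; beyond the scatter) from compound 4 to compound 1, 8.4-fold (0.93 log units) apart, beyond the scatter of two such steps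

The two settings differ both in the ring carrying the methoxy and in the rest of the molecule, so the compounds shown cannot separate the contribution of position from that of the core. Going by these compounds, whether the shift is specific to methoxy also remains open, and an ethoxy, a hydroxy or a fluorine at the same place on the core of compound 1 would test this.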